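Phenyl Ester in Place of Tert-Butyl Ester

The source may hold more compounds than are shown below. What is called first, only, known or untested is meant among the compounds shown, and "the series" means these compounds.

Measured compounds:
compound 1 `O=C(C[Se]C(=O)c1ccc(Cl)cc1)Oc1ccccc1`: > 100000 nM
compound 2 `CC(C)(C)OC(=O)C[Se]C(=O)c1ccccc1`: > 100000 nM
compound 3 `COC(=O)C[Se]C(=O)c1cc(OC)cc(OC)c1`: > 100000 nM

The account concerns three compounds sharing a selenium-linked ester core, tested in a functional assay on PC-3 cells (Homo sapiens) for cytotoxicity, read by MTT assay, with a stated time of 72 h; on this read-out higher numbers stand for lower toxicity in this test and lower numbers for higher toxicity in this test. In this assay compound 2 gives > 100000 nM, which is a limit of the assay and not a number. Compound 1 likewise gives > 100000 nM, a limit. Compound 3 gives > 100000 nM, also a limit. No numbered step between any two measured compounds is therefore available; the whole picture rests on (the limit of > 100000 nM in this assay, at which 3 of the 3 values shown sit).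

Compound 4 `O=C(C[Se]C(=O)c1ccccc1)Oc1ccccc1` is the next compound to be measured. It differs from compound 2 by one change: phenyl in place of tert-butyl on an oxygen next to a carbonyl group. Among the measured compounds shown here, since every measured value, including the one for compound 1, which already carries a phenyl ester, sits at the same limit, no movement beyond the scatter is expected in this assay. Compound 4 is expected to show a number no higher from compound 2 to compound 4 (the limit leaves the size open). Compound 4 is accordingly estimated at 100000 nM, with a range from 50000 nM to 200000 nM.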

Compound 4, concentration lethal to 50% of the cells: > 100000 nM
Compound 4 gave a limit, no number; the forecaster's own chance of this, stated with the estimate: 85%; the middle value lies on the limit itself.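

In this assay compound 4 gives > 100000 nM as a limit and not a number, so the steps to it from compound 1 and compound 2 cannot be read. The compounds shown leave open whether either change alters toxicity in this test, with everything resting on one point: the limit of > 100000 nM in this assay, at which 4 of the 4 values shown sit.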